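A Methyl Shift Between Two Amide Nitrogens

The source may hold more compounds than are shown below. What is called first, only, known or untested is meant among the compounds shown, and "the series" means these compounds.

Measured in an ADME assay on CEM-SS cells (Homo sapiens) for cytotoxicity, read by XTT assay, with a stated time of 6 days; on this read-out higher numbers stand for lower toxicity in this test and lower numbers for higher toxicity in this test:
- compound 1 `CCCC(=O)OCSc1ccccc1C(=O)NCCCNC(C)=O` gives 21.1 uM
- compound 2 `CCCC(=O)OCSc1ccccc1C(=O)NCC(=O)NC` gives > 100 uM, which is a limit of the assay and not a number
- compound 3 `CCCC(=O)OCSc1ccccc1C(=O)NCC(=O)N(C)C` gives 38.3 uM

For the measured compounds named here, compound 3 and compound 1 hold the only true numbers here, and these lie within the scatter of each other, as a 1.8-fold higher number from compound 1 to compound 3 (0.26 log units; within the scatter) shows. Compound 4 `CCCC(=O)OCSc1ccccc1C(=O)N(C)CC(N)=O` has not been measured. It differs from compound 3 by carrying (carbamoylmethyl)(methyl)amino in place of ((dimethylcarbamoyl)methyl)amino on a carbonyl carbon. The nearest measured change is the one that puts methyl in place of hydrogen on an amide-type nitrogen, an at least 2.6-fold lower number from compound 2 to compound 3 (0.41 log units; beyond the scatter), which lies beyond the scatter. That single step suggests that methyl count and placement can matter, but it does not match this change exactly. Only a small upward step is therefore expected in this assay: a 1.8-fold higher number from compound 3 to compound 4 (0.26 log units; within the scatter). Compound 4 is estimated at 70 uM, with an expected range from 30 uM to 150 uM.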

Compound 4, half-maximal toxic concentration: 55.3 uM
Compound 4: middle estimate off by 1.3-fold (0.10 log units), on the high side; low and high end bracket the measured number.
By their numbers in this assay, from the lowest: compounds 1, 3 and 4 (each within the scatter of the next, the first and the last beyond it). At a limit, above all of these: compound 2.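

In this assay, swapping ((dimethylcarbamoyl)methyl)amino for (carbamoylmethyl)(methyl)amino on this carbonyl carbon gives a difference too small to tell from noise: a 1.4-fold higher number from compound 3 to compound 4 (0.16 log units; within the scatter). The new group does separate from (3-acetamidopropyl)amino, a 2.6-fold higher number from compound 1 to compound 4 (0.42 log units; beyond the scatter), a gap that compound 3 did not open, as its values lie within the scatter of those of compound 1. Compound 2 stands at a limit of the assay and not a number, so its step, an at least 1.8-fold lower number from compound 2 to compound 4 (0.25 log units; that floor lies within the scatter), gives only a floor: the limit of > 100 uM in this assay, at which 1 of the 4 values shown sits.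

The compounds shown leave open how (carbamoylmethyl)amino, with no methyl on either nitrogen, would read on this carbonyl carbon. They also leave open whether an amine or a carboxylic acid in place of the terminal amide would change the toxicity number.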